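A few compounds are considered here, and "the series" means these few. Any claim that something is new, unique, unknown or untested is made for them only; others in the source may bear on it.

Compound 3 `N#Cc1cnc(NCc2cnccc2C(F)(F)F)cc1N[C@H]1CC[C@@H](C(N)=O)CC1` stands lowest of the three numbers in an assay on isolated protein for inhibition of protein kinase C delta type (Homo sapiens), read by TR-FRET, with a stated time of 2 h; a lower number here means a stronger inhibitor, a higher number a weaker inhibitor: compound 3 gives 400 nM, whereas compound 1 `N#Cc1cnc(NCc2cnccc2C(F)(F)F)cc1NC[C@H]1C[C@@H](O)C1` gives 4200 nM and compound 2 `N#Cc1cnc(NCc2cnccc2C(F)(F)F)cc1NCC1CCOCC1` gives 5000 nM. Both steps onto compound 3 were large, an 11-fold lower number from compound 1 to compound 3 (1.02 log units; beyond the scatter) and a 13-fold lower number from compound 2 to compound 3 (1.10 log units; beyond the scatter), while a 1.2-fold higher number from compound 1 to compound 2 (0.08 log units; within the scatter). Compound 4 `CC1(C)C[C@@H](Nc2cc(NCc3cnccc3C(F)(F)F)ncc2C#N)CC[C@@H]1O` alters compound 3 by 4-hydroxy-3,3-dimethylcyclohexyl in place of 4-carbamoylcyclohexyl on a nitrogen on an aromatic ring. Going by the values given here, no measured step exchanges substituents on a ring placed on the nitrogen on the aromatic ring; the large steps to compound 3 only show that this arrangement carries the gain, and it is kept in compound 4. The hydroxy of compound 1 belongs to a 3-hydroxycyclobutyl and offers no direct comparison. A modest loss is therefore expected, a 2.3-fold higher number from compound 3 to compound 4 (0.35 log units; beyond the scatter). Compound 4 is estimated at 900 nM, range 300 nM to 3000 nM.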

Compound 4, half-maximal inhibitory concentration: 2400 nM
Compound 4: middle estimate off by 2.7-fold (0.43 log units), on the low side, and the stated range covers the measured number.
By their numbers in this assay, from the lowest: compound 3; then compounds 4, 1 and 2 (each within the scatter of the next, the first and the last beyond it).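

On the nitrogen on the aromatic ring, a cyclohexyl group does not alone secure the low number of compound 3 in this assay: 4-hydroxy-3,3-dimethylcyclohexyl in place of 4-carbamoylcyclohexyl gives a clear loss (a 6.0-fold higher number from compound 3 to compound 4 (0.78 log units; beyond the scatter)). The same group still gives a modest gain over (oxan-4-yl)methyl (a 2.1-fold lower number from compound 2 to compound 4 (0.32 log units; beyond the scatter)), but no separation from (3-hydroxycyclobutyl)methyl (a 1.8-fold lower number from compound 1 to compound 4 (0.24 log units; within the scatter)). No available evidence explains these steps.

Open, on these data alone, is whether the carbamoyl or the two methyl groups govern the loss. A 4-carboxycyclohexyl, a 4-aminocyclohexyl and a 4-hydroxycyclohexyl without the methyl groups would separate these.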